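Isopropyl to Cyclopropyl: Expected Cytotoxicity Stays at the Limit

The compounds below may be only part of what the source reports. "The series", "measured", "known", "first", "only" and "open" are said of these compounds alone.

compound 1 `CCCNc1cc(Oc2c(OC)cc3cc(C#N)ccc3c2OC)nc(Nc2ccc(C#N)cc2)n1`: > 125000 nM
compound 2 `COc1cc2cc(C#N)ccc2c(OC)c1Oc1cc(NCC(C)C)nc(Nc2ccc(C#N)cc2)n1`: > 125000 nM

In an ADME assay on MT4 cells (Homo sapiens) for cytotoxicity, read by MTT assay, with a stated time of 5 days (a higher number here means that more compound is tolerated, a lower number that less compound is tolerated), compound 1 gives > 125000 nM, which is a limit of the assay and not a number. Compound 2 gives > 125000 nM, again only a limit. The step that the two limits leave unreadable from compound 1 to compound 2 therefore cannot be read. Both values sit at the limit of > 125000 nM in this assay, at which 2 of the 2 values shown sit, so compound 2 stands at the top of what this assay can report, with no numeric position of its own.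

Compound 3 `COc1cc2cc(C#N)ccc2c(OC)c1Oc1cc(NCC2CC2)nc(Nc2ccc(C#N)cc2)n1` differs from compound 2 by cyclopropyl in place of isopropyl on a saturated chain carbon bound to a nitrogen on an aromatic ring. No measured step bears on this change, since the only step shown is unreadable. The two limits shown suggest that compound 3 will again be tolerated up to the limit. Compound 3 is expected to give 150000 nM, with a range from 60000 nM to 400000 nM, so the expected step is a step that the limit leaves unreadable from compound 2 to compound 3, none beyond the scatter.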

Compound 3, half-maximal cytotoxic concentration: > 125000 nM
Compound 3 gave a limit, no number; the forecaster's own chance of this, stated with the estimate: 80%; the middle value does not contradict the limit.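

Among the compounds shown here, compound 1, compound 2 and compound 3 all stop at the same limit in this assay, so no step among them can be read: (the limit of > 125000 nM in this assay, at which 3 of the 3 values shown sit). As far as these compounds go, what stays open is how much of each compound the cells tolerate past that limit, and whether isopropyl and cyclopropyl differ there at all.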